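The compounds below may be only part of what the source reports. "The series", "measured", "known", "first", "only" and "open" are said of these compounds alone.

Compound 2 `CCCC[C@H](NC(=O)[C@H](CCCCN)NC(=O)[C@H](CCCNC(=N)N)NC(=O)c1ccc(/C=C2\SC(=O)N(c3ccc(C)cc3)C2=O)cc1)C(N)=O` gives 0.66 10^-6 cm/s in an ADME assay for permeability, using PAMPA; a higher number here means that the compound crosses the layer faster, a lower number that the compound crosses the layer more slowly. Compound 1 `CCCCC(C(=O)OC)N1C(=O)/C(=C/c2ccc(C(=O)N[C@@H](CCCNC(=N)N)C(=O)N[C@@H](CCCCN)C(=O)N[C@@H](CCCC)C(N)=O)cc2)SC1=S` gives 0.87 10^-6 cm/s and compound 3 `CCCC[C@H](NC(=O)[C@H](CCCCN)NC(=O)[C@H](CCCNC(=N)N)NC(=O)c1ccc(/C=C2\SC(=S)N(Cc3ccc(OC)cc3)C2=O)cc1)C(N)=O` gives 0.6 10^-6 cm/s, so the number for compound 2 sits between those two, and both gaps are within the scatter. Compound 4 `CCCC[C@H](NC(=O)[C@H](CCCCN)NC(=O)[C@H](CCCNC(=N)N)NC(=O)c1ccc(/C=C2\SC(=O)N(C3CCCCC3)C2=O)cc1)C(N)=O` differs from compound 2 in one place: cyclohexyl in place of 4-methylphenyl on an amide-type nitrogen in a ring. Going by the values given here, the only measured step at an amide-type nitrogen in a ring, a 1.5-fold lower number from compound 1 to compound 3 (0.16 log units; within the scatter), stayed within the scatter, so a change of the group on that nitrogen has so far not moved the number. For compound 4 no step beyond the scatter is therefore expected, no change at the digits printed from compound 2 to compound 4 (within the scatter). The estimate for compound 4 is 0.66 10^-6 cm/s, with a range from 0.4 10^-6 cm/s to 1.1 10^-6 cm/s.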

Compound 4, apparent permeability: 1.69 10^-6 cm/s
Compound 4: middle estimate off by 2.6-fold (0.41 log units), on the low side; the measured number lies above the stated range.
By their numbers in this assay, from the lowest: compounds 3, 2, 1 and 4 (each within the scatter of the next, the first and the last beyond it).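

In this assay, the group on the amide-type nitrogen in a ring can move the number: the change from 4-methylphenyl to cyclohexyl gives a 2.6-fold higher number from compound 2 to compound 4 (0.41 log units; beyond the scatter) at this position, whereas a 1.5-fold lower number from compound 1 to compound 3 (0.16 log units; within the scatter) had not shown such a step. Neither group has hydrogen-bond donors, hydrogen-bond acceptors or a net charge, so the printed differences are the aromatic ring against the non-aromatic ring and 7 against 6 heavy atoms. No measurement at hand accounts for the step.

A phenyl, a cyclopentyl or an open hexyl chain on that nitrogen could separate ring type from size. As far as these compounds go, whether a cyclohexyl carrying an amine or a carboxylic acid keeps the higher number remains open.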